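The source may report more compounds than this note shows. Statements on the series, on what has been measured and on what is new or still open speak of the compounds shown alone.

Compound 1, `O=C(/C(=C/c1ccccc1)CCl)c1ccccc1`, was tested in a functional assay on HeLa cells (Homo sapiens) for inhibition, read by sulforhodamine B assay, with a stated time of 48 h (a higher number here means a weaker inhibitor of growth, a lower number a stronger inhibitor of growth), and there compound 1 gives 23000 nM. Compound 2, `O=C(/C(=C/c1ccc(Cl)cc1)CCl)c1ccccc1`, differs from compound 1 by chloro in place of hydrogen on an aromatic carbon, and in this assay compound 2 gives 22000 nM. The step between them is a 1.0-fold lower number from compound 1 to compound 2 (0.02 log units; within the scatter), so the two numbers cannot be told apart.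

Compound 3, `CC(=O)OC/C(=C/c1ccc(Cl)cc1)C(=O)c1ccc(Cl)cc1`, has a different core from compound 1; the difference between the two cores is not broken down here. In this assay compound 3 gives 5700 nM, the lowest of the three numbers, and its gaps to compound 2 and to compound 1 both lie beyond the scatter of repeated measurements.

Compound 4, `CC(=O)OC/C(=C/c1ccc(Cl)cc1Cl)C(=O)c1ccc(Cl)cc1`, has not yet been measured. Compared with compound 3 it carries chloro in place of hydrogen on an aromatic carbon. Among the measured compounds shown here, this is the same kind of change as the one from compound 1 to compound 2, though the place is not the same: in compound 2 the chloro sits para to a large group, whereas in compound 4 it sits ortho to a large group and meta to a chloro group. The expectation for compound 4 rests only on that earlier step, which was a 1.0-fold lower number from compound 1 to compound 2 (0.02 log units; within the scatter), and on the value of compound 3, 5700 nM. Compound 4 is therefore expected to give about 5000 nM in this assay, with a likely range from 2500 nM to 11000 nM, which amounts to an expected step of a 1.1-fold lower number from compound 3 to compound 4 (0.06 log units; within the scatter).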

Compound 4, concentration for 50% growth inhibition: 19000 nM
For compound 4 the middle estimate is 3.8-fold (0.58 log units) below the measured one, outside the stated range (above it).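

On the core of compound 3, going from 4-chlorophenyl to 2,4-dichlorophenyl gives a 3.3-fold higher number from compound 3 to compound 4 (0.52 log units; beyond the scatter), so in this assay the added chloro goes with weaker growth inhibition on this core. Set beside the earlier step, the result shows that the change cannot be carried as a fixed increment from one core to the other in this series: the same change on two cores in this assay, a 1.0-fold lower number (0.02 log units; within the scatter) from compound 1 to compound 2 and a 3.3-fold higher number (0.52 log units; beyond the scatter) from compound 3 to compound 4, 3.5-fold (0.54 log units) apart, beyond the scatter of two such steps

This does not show that the core alone sets the outcome, since the chloro enters a different place in each step and the two steps also start from different cores, so the pair cannot separate place from core, and one step on each core supports no general rule.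

The compounds shown leave open whether a chloro at the place it takes in compound 4 would have the same outcome on the core of compound 1, and whether a chloro at the place it takes in compound 2 would leave the number unchanged on the core of compound 3. They also leave open how other groups at the place taken by the new chloro, such as fluoro, methyl or methoxy, would compare, and whether an amine or a hydroxyl in place of the acetate would change the picture.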